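Hydroxyazetidine Amide in Place of a Diethylamine Side Chain

This account rests on a few compounds, and the source may have more. Where it says the series, first, only, none or still open, it means among the compounds named here.

The measured compounds in an ADME assay on microsomes from liver (Mus musculus) for metabolic stability, read by mass spectrometry, with a stated time of 40 min, tested at 1 uM (a lower number here means that less of the compound is left, a higher number that more of the compound is left), are:
- compound 1 `COc1cc(N2CCC(C(=O)N3CCOCC3)CC2)ccc1Nc1nc(NC2CCCCC2)c2nc[nH]c2n1` gives 70%
- compound 2 `COc1cc(N2CCC(CC(=O)N3CCOCC3)CC2)ccc1Nc1nc(NC2CCCCC2)c2nc[nH]c2n1` gives 61%
- compound 3 `CCN(CC)CC1CCN(c2ccc(Nc3nc(NC4CCCCC4)c4nc[nH]c4n3)c(OC)c2)CC1` gives 47%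

Compound 3 stands lowest of the three, and both of its steps from the others lie beyond the scatter: a number 23 percentage points lower from compound 1 to compound 3 (beyond the scatter) and a number 14 percentage points lower from compound 2 to compound 3 (beyond the scatter). By contrast, a number 9 percentage points lower from compound 1 to compound 2 (within the scatter) stays within the scatter.

Compound 4 `COc1cc(N2CCC(C(=O)N3CC(O)C3)CC2)ccc1Nc1nc(NC2CCCCC2)c2nc[nH]c2n1` is not yet measured. It differs from compound 3 in one place: (3-hydroxyazetidin-1-yl)carbonyl in place of (diethylamino)methyl on a saturated ring carbon. The two measured steps that bear on this change both run from an amide carbonyl on the same ring to the diethylamino group, and both ran downward in this assay, the first by a modest amount and the second by a modest amount as well. The change to compound 4 runs the other way, back toward a carbonyl-linked cyclic amine, though the ring is now a smaller one bearing a hydroxyl. One therefore expects a step upward, beyond the scatter, of roughly the size seen between compound 1 and compound 3; the estimated step is a number 19 percentage points higher from compound 3 to compound 4 (beyond the scatter). For compound 4 the estimate in this assay is 66%, with a range from 50% to 80%.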

Compound 4, percent of the compound remaining: 65%
The estimate for compound 4 lay 1 percentage points above the measured number; measured number inside the range.
By their numbers in this assay, from the lowest: compound 3; then compounds 2, 4 and 1 (each within the scatter of the next).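

In this assay, the (3-hydroxyazetidin-1-yl)carbonyl group on the saturated ring carbon gives a number 18 percentage points higher from compound 3 to compound 4 (beyond the scatter), so a second kind of carbonyl-linked cyclic amine now stands apart from the diethylamino side chain. The morpholin-4-yl and 3-hydroxyazetidin-1-yl groups on the carbonyl carbon cannot be told apart here, with a number 5 percentage points lower from compound 1 to compound 4 (within the scatter), and neither can this group and the ((morpholin-4-yl)carbonyl)methyl group, with a number 4 percentage points higher from compound 2 to compound 4 (within the scatter). Among the compounds shown here, at this position, the three amides stay within the scatter of each other, while compound 3, the only compound without a carbonyl in this group, stands apart from all of them.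

The compounds shown leave open how a plain azetidine amide, a piperidine amide or a carboxylic acid at this ring carbon would read. Nothing presented here accounts for the gap between compound 3 and the amides.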